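Arylpiperazine hexanamides at the serotonin 7 receptor: compound 4

This account rests on a few compounds, and the source may have more. Where it says the series, first, only, none or still open, it means among the compounds named here.

Measured compounds:
compound 1 `O=C(CCCCCN1CCN(c2noc3ccccc23)CC1)NC1CCCc2ccccc21` gives 125 nM
compound 2 `COc1ccc2oc(N3CCN(CCCCCC(=O)NC4CCCc5ccccc54)CC3)nc2c1` gives 704 nM
compound 3 `CC(=O)c1ccc(N2CCN(CCCCCC(=O)NC3CCCc4ccccc43)CC2)cc1` gives 2640 nM

All three share the same core, and in an assay on HEK293 cells for displacement of a labelled ligand from 5-hydroxytryptamine receptor 7 (Rattus norvegicus) (a lower number here means a stronger inhibitor, a higher number a weaker inhibitor), compound 3 gives the highest number of the set. The step of a 21-fold higher number from compound 1 to compound 3 (1.32 log units; beyond the scatter) is large, and the step of a 3.8-fold higher number from compound 2 to compound 3 (0.57 log units; beyond the scatter) is modest; both lie beyond the scatter, so compound 3 stands as the weakest of the measured compounds in this assay.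

Compound 4 `NC(=O)c1ccccc1N1CCN(CCCCCC(=O)NC2CCCc3ccccc32)CC1` is not yet measured. It differs from compound 3 in one place: 2-carbamoylphenyl in place of 4-acetylphenyl on an amine nitrogen in a ring. Going by the values given here, none of the measured steps exchanges one phenyl group for another; the steps from compound 1 and compound 2 to compound 3 replace a bicyclic group by 4-acetylphenyl, and they say nothing direct about a carbamoyl group on the phenyl ring. The expectation therefore rests on little, and a step of a 1.3-fold lower number from compound 3 to compound 4 (0.12 log units; within the scatter) within the usual scatter is expected, with no clear direction. Compound 4 is estimated at 2000 nM, in the range 500 nM to 8000 nM.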

Compound 4, inhibition constant: 229 nM
Compound 4: middle estimate off by 8.7-fold (0.94 log units), on the high side; measured number outside the range, below it.
By their numbers in this assay, from the lowest: compounds 1 and 4 (each within the scatter of the next); then compound 2; then compound 3.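

In this assay a phenyl group on this amine nitrogen is not tied to a weak number, since a 12-fold lower number from compound 3 to compound 4 (1.06 log units; beyond the scatter) comes from exchanging 4-acetylphenyl for 2-carbamoylphenyl, a change that keeps the heavy-atom count and adds one hydrogen-bond donor. A group with a single ring can also match or pass the two-ring groups here: a 3.1-fold lower number from compound 2 to compound 4 (0.49 log units; beyond the scatter) is beyond the scatter, while a 1.8-fold higher number from compound 1 to compound 4 (0.26 log units; within the scatter) leaves compound 4 level with compound 1. Nothing available explains why this exchange has so large an effect.

The two phenyl groups differ in both the substituent and its position, so the compounds shown cannot separate the carbamoyl group from the place it holds. On these data alone, it also remains open whether a carboxylic acid or a nitrile at that place would keep the number near that of compound 4.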